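Quinoxaline-type diamines: aryl ether to aryl thioether

This account rests on a few compounds, and the source may have more. Where it says the series, first, only, none or still open, it means among the compounds named here.

Measured so far:
compound 1, `Nc1cc(N)c2nc(-c3ccccc3)c(Oc3ccc(Cl)c(Cl)c3)nc2c1`, 14100 nM
compound 2, `CCOC(=O)[C@H](CCC(=O)O)NC(=O)c1ccc(CNc2nc3cc(N)cc(N)c3nc2-c2ccccc2)cc1`, < 100000 nM
compound 3, `CCOC(=O)[C@H](CCC(=O)O)NC(=O)c1ccc(Oc2nc3cc(N)cc(N)c3nc2-c2ccccc2)cc1`, 53700 nM

In a functional assay on MCF7 cells (Homo sapiens) for inhibition, read by sulforhodamine B assay, with a stated time of 48 h (on this read-out lower numbers stand for stronger inhibition of growth and higher numbers for weaker inhibition of growth), compound 1 gives 14100 nM, the lowest of the two numbers available. Compound 3 gives 53700 nM in this assay, a gap from compound 1 that lies beyond the usual scatter. Compound 2 returns only a limit, < 100000 nM, and so sits at the limit of < 100000 nM in this assay, at which 1 of the 3 values shown sits; it gives no number to compare.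

Compound 4, `Nc1cc(N)c2nc(-c3ccccc3)c(Sc3ccc(F)cc3)nc2c1`, is not yet measured. Relative to compound 1 the change is (4-fluorophenyl)sulfanyl in place of 3,4-dichlorophenoxy on an aromatic carbon. Going by the values given here, no measured pair in the set shares this change, so no step can be read from the data. The aryl group on that carbon is kept, only its halogen pattern and the linking atom alter; the expectation is therefore a small step, of no clear direction, from compound 1 to compound 4 in this assay, a 1.1-fold higher number from compound 1 to compound 4 (0.05 log units; within the scatter). Compound 4 is expected to give 16000 nM, with a range from 5000 nM to 50000 nM.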

Compound 4, concentration for 50% growth inhibition: 20000 nM
Estimate against measurement, compound 4: 1.3-fold (0.10 log units) below; the measured number falls inside the stated range.
By their numbers in this assay, from the lowest: compounds 1 and 4 (each within the scatter of the next); then compound 3.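

In this assay, (4-fluorophenyl)sulfanyl in place of 3,4-dichlorophenoxy on the aromatic carbon next to the ring nitrogen gives a 1.4-fold higher number from compound 1 to compound 4 (0.15 log units; within the scatter), so this position accepts a new linking atom and a new halogen pattern together without a step beyond the scatter. The two alterations sit in one step, so the share of each cannot be read, and opposing contributions cannot be excluded. No measured property at hand bears on this step.

Open, from the compounds shown here alone, is how 3,4-dichlorophenylsulfanyl or 4-fluorophenoxy would read on this carbon, since either would separate the linking atom from the halogen pattern. Also open, going by these compounds, is what a non-aryl group, such as a morpholine or a piperazine, would give at the same place on the shared core.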